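Hydroxymethyl to methyl in a series of triterpenoid analogs

The source may hold more compounds than are shown below. What is called first, only, known or untested is meant among the compounds shown, and "the series" means these compounds.

Compound 1 `CC1(C)C(CC[C@@H]2[C@@]3(C)CC[C@@H](O)C(C)(C)O[C@@H]3CC[C@]2(C)O)C(CO)=CCC2C1CC[C@@]2(C)O`: > 50000 nM
Compound 2 `CC1=CCC2C(CC[C@@]2(C)O)C(C)(C)C1CC[C@@H]1[C@@]2(C)CCC(=O)C(C)(C)O[C@@H]2CC[C@]1(C)O`: > 50000 nM
Compound 3 `CC1(C)O[C@@H]2CC[C@](C)(O)[C@H](CCC3C(CO)=CCC4C(CC[C@@]4(C)O)C3(C)C)[C@@]2(C)CCC1=O`: > 50000 nM

Of the compounds shown here, three have been tested in a functional assay on KB-C2 cells (Homo sapiens) for cytotoxicity, read by MTT assay, with a stated time of 68 h; a lower number here means a stronger inhibitor, a higher number a weaker inhibitor. In this assay compound 1 gives > 50000 nM, a limit of the assay and not a number. Compound 2 gives > 50000 nM, again a limit. Compound 3 gives > 50000 nM, also a limit. The difference between the cores of compound 1 and compound 3 is not broken down here.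

Compound 3 and compound 2 differ in one place (hydrogen in place of hydroxy on a saturated chain carbon bound to a double-bonded ring carbon). The step that the two limits leave unreadable from compound 3 to compound 2 cannot be sized due to the limit of > 50000 nM in this assay, at which 3 of the 3 values shown sit, since both ends sit at the same limit.

Compound 4 `CC1=CCC2C(CC[C@@]2(C)O)C(C)(C)C1CC[C@@H]1[C@@]2(C)CC[C@@H](O)C(C)(C)O[C@@H]2CC[C@]1(C)O` has not yet been measured in this assay. It differs from compound 1 in the same way (hydrogen in place of hydroxy on a saturated chain carbon bound to a double-bonded ring carbon), at the same place. For the measured compounds named here, since compound 1 gives only a limit, and the one measured instance of this change did not move either partner off that limit, compound 4 is expected to behave alike. The step from compound 1 to compound 4 is estimated as a step that the limit leaves unreadable from compound 1 to compound 4, with the expectation that the assay will again report only a limit. On that basis compound 4 is estimated at 60000 nM, in a range from 20000 nM to 200000 nM.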

Compound 4, half-maximal inhibitory concentration: > 50000 nM
Compound 4: no number, only a limit (the forecaster's own chance of this, stated with the estimate: 85%); the middle value is on the limit's open side.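

No step can be read from compound 1 to compound 4 in this assay, as both compounds give only a limit of the assay and not a number: the limit of > 50000 nM in this assay, at which 4 of the 4 values shown sit.

The compounds shown leave open whether the change from hydroxymethyl to methyl alters cytotoxicity at all, and how any of these four compounds would compare with the others if given a measured number.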